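A few compounds are considered here, and "the series" means these few. Any claim that something is new, unique, unknown or untested is made for them only; others in the source may bear on it.

Compound 1 `CC(C)C[C@H](NC(=O)[C@@H]1CNC(=O)N1)C(=O)N1CCC[C@H]1C(N)=O` gives 40% in a functional assay on the whole organism with Rattus norvegicus as the target, at a dose of 80 mg/kg; on this read-out lower numbers stand for less inhibition and higher numbers for more inhibition at the one dose given (going by the name of the read-out).
Compound 2 `CC(C)C[C@H](NC(=O)[C@@H]1CCC(=O)O1)C(=O)N1CCC[C@H]1C(N)=O` gives 40% in this assay.
Compound 3 `CCC[C@H](NC(=O)[C@@H]1CCC(=O)N1)C(=O)N[C@@H](CC(C)C)C(N)=O` gives 20% in this assay.

Compound 3 stands lowest of the three numbers; compound 1 and compound 2 both lie higher, each by a gap beyond the usual scatter. The unmeasured compound 4 `CCC[C@H](NC(=O)[C@@H]1CCC(=O)N1)C(=O)N[C@H](CCSC)C(N)=O` differs from compound 3 in one place: a group of 8 heavy atoms (5 carbon, 1 nitrogen, 1 oxygen, 1 sulfur; no ring) in place of a group of 8 heavy atoms (6 carbon, 1 nitrogen, 1 oxygen; no ring), on an amide-type nitrogen. For the measured compounds named here, the only measured step, no change at the digits printed from compound 1 to compound 2 (within the scatter), concerns a ring swap on a carbonyl carbon, not the chain on the amide-type nitrogen, so no measured step bears directly on this change. With no guide in the data, compound 4 is expected to show a step of no change at the digits printed from compound 3 to compound 4 (within the scatter) that stays within the scatter. Compound 4 is therefore estimated at 20%, with a range from 5% to 40%.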

Compound 4, a percentage reported as inhibition, in the whole organism at one dose (the size of the read-out at that dose, not a potency): 20%
For compound 4 middle estimate and measured number coincide at the digits printed; the range from low to high includes it.
By their numbers in this assay, from the lowest: compounds 3 and 4 (each within the scatter of the next); then compounds 1 and 2 (each within the scatter of the next).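

On the amide-type nitrogen, the 1-carbamoyl-3-methylbutyl group gives way to a sulfur-containing group of 8 heavy atoms with no change at the digits printed from compound 3 to compound 4 (within the scatter) in this assay. For the compounds shown here, this is the first measured step at this place, and it shows that, at this dose, this exchange leaves the read-out within the scatter. Nothing available here offers an explanation for this result.

On these data alone, whether an amine, a carboxylic acid or a longer carbon chain at this place would shift the number remains open. So does whether the same exchange would leave the number unmoved on another core.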